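The source may report more compounds than this note shows. Statements on the series, on what has been measured and on what is new or still open speak of the compounds shown alone.

Compound 3 `Cc1cccc(N2CCN(c3nc(C(F)(F)F)ccc3CNC(=O)C(C)c3ccc(NS(C)(=O)=O)c(F)c3)CC2)c1` gives 3.4 nM in a functional assay on CHO-K1 cells for antagonist activity at transient receptor potential cation channel subfamily V member 1 (Homo sapiens), read by FLIPR (a higher number here means a weaker inhibitor, a lower number a stronger inhibitor), which places it second highest of the three numbers measured. Compound 1 `CC(C(=O)NCc1ccc(C(F)(F)F)nc1NC1CCCCC1)c1ccc(NS(C)(=O)=O)c(F)c1` gives 20.4 nM in this assay, and compound 2 `CC(C(=O)NCc1ccc(C(F)(F)F)nc1N1CC=CCC1)c1ccc(NS(C)(=O)=O)c(F)c1` gives 0.3 nM; compound 3 therefore sits between them, closer to compound 1 than to compound 2.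

Compound 4 `CC(C(=O)NCc1ccc(C(F)(F)F)nc1N1CCN(c2ncccc2Cl)CC1)c1ccc(NS(C)(=O)=O)c(F)c1` has not yet been measured. It differs from compound 3 in one place: 3-chloropyridin-2-yl in place of 3-methylphenyl on an amine nitrogen in a ring. For the measured compounds named here, the only step measured so far is a 68-fold lower number from compound 1 to compound 2 (1.83 log units; beyond the scatter), and it concerns the group on the aromatic carbon of the shared core, not the substituent carried on the amine nitrogen in a ring where compound 3 and compound 4 differ. Going by the values given here, no measured pair tests an exchange of that kind, so nothing in the data points to a large shift in either direction, and the expectation rests on the change being a swap of one six-membered aromatic ring for another of the same size.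

Compound 4 is therefore expected to stay close to compound 3, with the estimated step of a 1.0-fold higher number from compound 3 to compound 4 (0.01 log units; within the scatter) not beyond the scatter. Compound 4 is estimated at 3.5 nM in this assay, within a range from 1 nM to 12 nM.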

Compound 4, inhibition constant: 2.1 nM
Estimate against measurement, compound 4: 1.7-fold (0.22 log units) above; the measured number falls inside the stated range.
By their numbers in this assay, from the lowest: compound 2; then compounds 4 and 3 (each within the scatter of the next); then compound 1.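

At the group on the amine nitrogen in a ring, this assay gives a 1.6-fold lower number from compound 3 to compound 4 (0.21 log units; within the scatter), so compound 3 and compound 4 cannot be told apart. For the compounds shown here, this is the first measured exchange at this position, as the only earlier step concerned the group on the aromatic carbon of the shared core. It shows that 3-methylphenyl can give way to 3-chloropyridin-2-yl, a group of the same heavy-atom count that brings a ring nitrogen, a chlorine and a hydrogen-bond acceptor, without a change in the number beyond the scatter. No available evidence bears on why the two groups read alike here. The compounds shown leave open whether the ring nitrogen and the chlorine would each be tolerated alone, since both enter together in this single exchange. They also leave open whether the position would accept something other than a six-membered aromatic ring, such as a carboxylic acid, an aliphatic amine or a longer alkyl chain on the same amine nitrogen.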